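Replacing Cyano with Difluoromethoxy: an Estimate

This account rests on a few compounds, and the source may have more. Where it says the series, first, only, none or still open, it means among the compounds named here.

Compound 1 `COCc1nc2c(NC(C3CC3)C3CC3)nc(C)nc2n1-c1ccc(OC)cc1` gives 157 nM in a functional assay on CHO cells for antagonist activity at corticotropin-releasing factor receptor 1 (Homo sapiens), read by cAMP accumulation; on this read-out lower numbers stand for stronger inhibition and higher numbers for weaker inhibition. Compound 2 `COc1ccc(-n2c(CC3CC3)nc3c(NC(C4CC4)C4CC4)nc(C)nc32)cc1` gives 308 nM. Compound 3 `Cc1nc(NC(C2CC2)C2CC2)c2nc(C)n(-c3ccc(C#N)cc3)c2n1` gives 62 nM.

Compound 3 has the lowest number of the three, with compound 1 nearest and compound 2 furthest, both gaps beyond the scatter. Compound 4 `Cc1nc(NC(C2CC2)C2CC2)c2nc(C)n(-c3ccc(OC(F)F)cc3)c2n1` has not yet been measured; it differs from compound 3 by difluoromethoxy in place of cyano on an aromatic carbon. Among the measured compounds shown here, the only measured step, a 2.0-fold higher number from compound 1 to compound 2 (0.29 log units; within the scatter), concerns a group on a saturated chain carbon rather than the group on an aromatic carbon of a six-membered aromatic ring of carbon only, so it bears on this change only as a sign that a single-group swap has moved the number little. For the measured compounds named here, with no direct precedent, a modest upward step is expected, a 1.9-fold higher number from compound 3 to compound 4 (0.29 log units; within the scatter). Compound 4 is estimated at 120 nM, with a range from 40 nM to 360 nM.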

Compound 4, inhibition constant: 5 nM
The estimate for compound 4 lay 24-fold (1.38 log units) above the measured number, outside the stated range (below it).
By their numbers in this assay, from the lowest: compound 4; then compound 3; then compounds 1 and 2 (each within the scatter of the next).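

In this assay, difluoromethoxy in place of cyano on an aromatic carbon para to a large group gives a 12-fold lower number from compound 3 to compound 4 (1.09 log units; beyond the scatter) and marks this position as one where the choice of group can move the number strongly. The earlier compounds shown here showed only a step on a saturated chain carbon, so they gave no view of this. Nothing measured here accounts for the size of the step. From the compounds shown here alone, how trifluoromethoxy or a chlorine at this position would compare with difluoromethoxy on the core of compound 3 stays open. So does whether the same swap would give a similar step with the other chain groups of compound 1 and compound 2.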